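This account rests on a few compounds, and the source may have more. Where it says the series, first, only, none or still open, it means among the compounds named here.

Compound 1 `N#Cc1ccccc1C1CCN(CCCNC(=O)C2=CNC(=O)N[C@@H]2c2ccc(F)c(F)c2)CC1` gives 0% in an in vivo ADME assay on the whole organism (Rattus norvegicus) for pharmacokinetics; on this read-out higher numbers stand for higher oral bioavailability and lower numbers for lower oral bioavailability. Compound 2 `CC1=C(C(=O)NCCCN2CCC(c3ccccc3C#N)CC2)[C@@H](c2ccc(F)c(F)c2)NC(=O)N1` gives 0% in this assay. Compound 3 `N#Cc1cc(F)ccc1C1CCN(CCCNC(=O)C2=CNC(=O)N[C@@H]2c2ccc(F)c(F)c2)CC1` gives 0% in this assay.

Compound 4 `CC1=C(C(=O)NCCCN2CCC(c3ccc(F)cc3C#N)CC2)[C@@H](c2ccc(F)c(F)c2)NC(=O)N1` has not yet been measured. It arises from compound 3 by methyl in place of hydrogen on a double-bonded ring carbon. The same change, (methyl in place of hydrogen on a double-bonded ring carbon), was already made once, where it gave no change at the digits printed from compound 1 to compound 2 (within the scatter). The two cores differ by fluoro in place of hydrogen on an aromatic carbon, which gave no change at the digits printed from compound 1 to compound 3 (within the scatter), so all three measured compounds sit at the bottom of the scale.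

Because no change at the digits printed from compound 1 to compound 2 (within the scatter) showed nothing at all, the expected step is no change at the digits printed from compound 3 to compound 4 (within the scatter). Compound 4 is therefore estimated at 0%, with a likely range from 0% to 5%. Among the measured compounds shown here, nothing among the measured compounds suggests that a single added methyl would lift a reading that is at zero in every neighbour.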

Compound 4, oral bioavailability: 0%
Estimate against measurement, compound 4: no gap at the digits printed; the measured number falls inside the stated range.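

In this assay, methyl in place of hydrogen on a double-bonded ring carbon gives no change at the digits printed from compound 3 to compound 4 (within the scatter), which matches the step on the other core: the same change on two cores in this assay, no change at the digits printed (within the scatter) from compound 1 to compound 2 and no change at the digits printed (within the scatter) from compound 3 to compound 4, 0 percentage points apart, within the scatter of two such steps. Fluoro in place of hydrogen on an aromatic carbon gives no change at the digits printed from compound 2 to compound 4 (within the scatter), and this also matches its earlier step: the same change on two cores in this assay, no change at the digits printed (within the scatter) from compound 1 to compound 3 and no change at the digits printed (within the scatter) from compound 2 to compound 4, 0 percentage points apart, within the scatter of two such steps. Among the compounds shown here, all four compounds sit at the bottom of the scale, so this agreement shows only that neither change, alone or combined, lifts the reading from there; it does not show how either change would carry over to a core with measurable oral bioavailability.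

From the compounds shown here alone, it remains open whether any other group, such as an amine, a carboxylic acid or a longer chain, would raise the reading.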